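Removing the hydroxy group from compound 3

A few compounds are considered here, and "the series" means these few. Any claim that something is new, unique, unknown or untested is made for them only; others in the source may bear on it.

Compound 1 `COc1ccc2c(c1)/C(=C/c1c(-c3ccncc3)nc3sccn13)C(=O)N2C`: 500 nM
Compound 2 `COc1ccc2c(c1)/C(=C\c1c(OC)nc3sc(C)cn13)C(=O)N2`: 650 nM
Compound 3 `COc1nc2sc(C)cn2c1/C=C1/C(=O)Nc2ccc(O)cc21`: 6580 nM

In a functional assay on cells (Renal cancer cell line, Homo sapiens) for cytotoxicity, read by sulforhodamine B assay, with a stated time of 48 h (on this read-out higher numbers stand for weaker inhibition of growth and lower numbers for stronger inhibition of growth), compound 3 has the highest number of the three. Compound 4 `COc1nc2sc(C)cn2c1/C=C1/C(=O)Nc2ccccc21` differs from it in one place: hydrogen in place of hydroxy on an aromatic carbon. Going by the values given here, one measured step bears on this change. Replacing the methyl on the oxygen of compound 2 with hydrogen gave a large step, a 10-fold higher number from compound 2 to compound 3 (1.01 log units; beyond the scatter). Among the compounds with values here, no compound with hydrogen on that carbon has been measured, so the evidence is indirect. A lower number is expected, in a step probably smaller than that one, as a 4.1-fold lower number from compound 3 to compound 4 (0.61 log units; beyond the scatter). The estimate for compound 4 is 1600 nM, with an expected range of 450 nM to 6000 nM.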

Compound 4, concentration for 50% growth inhibition: 3530 nM
Compound 4: the middle estimate sits 2.2-fold (0.34 log units) below what was measured; measured number inside the range.
By their numbers in this assay, from the lowest: compounds 1 and 2 (each within the scatter of the next); then compounds 4 and 3 (each within the scatter of the next).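

In this assay, hydrogen and hydroxy on this aromatic carbon cannot be told apart (a 1.9-fold lower number from compound 3 to compound 4 (0.27 log units; within the scatter)). Methoxy on the same carbon stands apart from hydrogen as well (a 5.4-fold higher number from compound 2 to compound 4 (0.73 log units; beyond the scatter)), so the large earlier step reads as the loss of methoxy rather than a penalty for hydroxy. Nothing available explains this difference. On these data alone, whether ethoxy, a longer ether or an amine on this carbon would match methoxy remains open. So does whether fluorine would behave like hydrogen.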